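Working notes: from 4-bromophenyl to 3-amino-4-methoxyphenyl

The source may hold more compounds than are shown below. What is called first, only, known or untested is meant among the compounds shown, and "the series" means these compounds.

Measured in a functional assay on K-562R cells (Homo sapiens) for cytotoxicity, read by MTT assay, with a stated time of 48 h (on this read-out lower numbers stand for stronger inhibition and higher numbers for weaker inhibition), so far
- compound 1 `COc1ccc(-c2c[nH]c(=O)n2-c2cc(OC)c(OC)c(OC)c2)cc1OC` gives > 50000 nM (a limit)
- compound 2 `COc1ccc(-c2cn(C(=O)Nc3cc(OC)c(OC)c(OC)c3)c(=O)n2-c2cc(OC)c(OC)c(OC)c2)cc1N` gives 9400 nM
- compound 3 `COc1cc(-n2c(-c3ccc(Br)cc3)cn(C(C)=O)c2=O)cc(OC)c1OC` gives 900 nM

Compound 3 at 900 nM holds the lowest number in the series, and compound 2 at 9400 nM lies higher, beyond the scatter. Compound 1 at > 50000 nM is a limit of the assay and not a number.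

Compound 4 `COc1ccc(-c2cn(C(C)=O)c(=O)n2-c2cc(OC)c(OC)c(OC)c2)cc1N` has 3-amino-4-methoxyphenyl in place of 4-bromophenyl on an aromatic carbon and keeps the acetyl group of compound 3. For the measured compounds named here, no measured pair isolates this change. Going by the values given here, compound 4 shares its new group with compound 2 at 9400 nM and its acetyl group with compound 3 at 900 nM as the only guides. In this assay the expected step of a 1.5-fold lower number from compound 3 to compound 4 (0.18 log units; within the scatter) is none beyond the scatter, with real uncertainty in both directions. For compound 4 the estimated value is 600 nM with an expected range from 50 nM to 6000 nM in this assay.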

Compound 4, half-maximal inhibitory concentration: 49300 nM
Compound 4: the middle estimate sits 82-fold (1.91 log units) below what was measured, outside the stated range (above it).
By their numbers in this assay, from the lowest: compound 3; then compound 2; then compound 4. At a limit, above all of these: compound 1.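

In this assay, with the acetyl group held, 3-amino-4-methoxyphenyl in place of 4-bromophenyl on this aromatic carbon gives a 55-fold higher number from compound 3 to compound 4 (1.74 log units; beyond the scatter). For the compounds shown here, this is the first single-place comparison, and it shows that the group at this position alone can move the read-out far beyond the scatter. The new number lies close to the top of what this assay reports: the limit of > 50000 nM in this assay, at which 1 of the 4 values shown sits.

Going by these compounds, whether the step follows the loss of bromine or the arrival of the amine and methoxy groups stays open. A 4-chlorophenyl, a 4-methoxyphenyl or a 3-aminophenyl group at this position would separate these.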